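A few compounds are considered here, and "the series" means these few. Any claim that something is new, unique, unknown or untested is made for them only; others in the source may bear on it.

Compound 1 `C=C1[C@](C)(O)CC[C@@]1(C)c1ccc(C)c(O)c1`: in a functional assay on HCT-8 cells (Homo sapiens) for cytotoxicity, read by MTT assay (a lower number here means a stronger inhibitor, a higher number a weaker inhibitor), compound 1 gives > 10 ug/mL, which is a limit of the assay and not a number.
Compound 2 `Cc1ccc([C@]2(C)CC[C@@H]3C[C@@]32C)cc1O`: in this assay compound 2 gives > 10 ug/mL, again a limit.
Compound 3 `Cc1ccc([C@]2(C)CC[C@H](C(C)(C)O)O2)cc1`: in this assay compound 3 gives > 10 ug/mL, also a limit.

None of the three measured compounds has a numerical value in this assay; all three sit at the limit of > 10 ug/mL in this assay, at which 3 of the 3 values shown sit. Compound 3 therefore stands nowhere in particular among them: it shares the same limit as compound 1 and compound 2, and nothing separates the three on the numbers shown.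

The step from compound 3 to the unmeasured compound 4 `Cc1ccc([C@]2(C)CC[C@@H](C(C)(C)O)O2)cc1` is a change of configuration only: the two compounds have the same atoms and bonds and differ only in configuration as drawn: 1 of 2 stereo elements differ; a stereocentre at a saturated ring carbon is drawn R in compound 3 and S in compound 4. With no measured step among these compounds to lean on, and with every measured value resting at a limit, there is no ground to expect a move in this assay beyond the usual scatter in either direction. The step from compound 3 to compound 4 is expected to be a step that the limit leaves unreadable from compound 3 to compound 4, essentially none. Compound 4 is estimated at 20 ug/mL, between 10 ug/mL and 40 ug/mL, most likely reported as a limit as well.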

Compound 4, half-maximal inhibitory concentration: > 10 ug/mL
Compound 4: no number, only a limit; the forecaster's own chance of this, stated with the estimate: 85%; the middle value is on the limit's open side.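

In this assay compound 4 gives > 10 ug/mL, a limit and not a number, like compound 3, and the step between these two cannot be read. On these data alone, how strong any of compound 1, compound 2, compound 3 and compound 4 really is remains open, as does whether this change of configuration matters at all.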